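A few compounds are considered here, and "the series" means these few. Any claim that something is new, unique, unknown or untested is made for them only; others in the source may bear on it.

Compound 1 `CCCCC(O)CC(=O)O[C@H](CC=C(C)C)C1=CC(=O)c2c(O)ccc(O)c2C1=O`: in a functional assay on DU-145 cells (Homo sapiens) for cytotoxicity, read by MTT assay (a higher number here means a weaker inhibitor, a lower number a stronger inhibitor), compound 1 gives 45300 nM.
Compound 2 `CC(C)=CC[C@@H](OC(=O)c1ccoc1)C1=CC(=O)c2c(O)ccc(O)c2C1=O`: in this assay compound 2 gives only a limit, > 100000 nM.

Compound 2 stands at the weak end of the two values, at the limit of > 100000 nM in this assay, at which 1 of the 2 values shown sits, so no number is known for it. Compound 3 `CC(=O)OCCC(=O)O[C@H](CC=C(C)C)C1=CC(=O)c2c(O)ccc(O)c2C1=O` differs from compound 2 by 2-acetoxyethyl in place of furan-3-yl on a carbonyl carbon. For the measured compounds named here, the one measured step, an at least 2.2-fold higher number from compound 1 to compound 2 (0.34 log units; beyond the scatter), went from an open chain on that carbonyl carbon to furan-3-yl and weakened inhibition. Returning to an open chain is expected to reverse part of that, a modest step downward, an at least 1.6-fold lower number from compound 2 to compound 3 (0.22 log units; that floor lies within the scatter). Compound 3 is therefore estimated at 60000 nM, within 25000 nM to 150000 nM.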

Compound 3, half-maximal inhibitory concentration: 15700 nM
Estimate against measurement, compound 3: 3.8-fold (0.58 log units) above; the whole stated range lies above it.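

Putting 2-acetoxyethyl in place of furan-3-yl on this carbonyl carbon gives an at least 6.3-fold lower number from compound 2 to compound 3 (0.80 log units; beyond the scatter). The open chains also differ from one another at this position: acetoxymethyl in place of 1-hydroxypentyl gives a 2.9-fold lower number from compound 1 to compound 3 (0.46 log units; beyond the scatter). The first of these steps has no upper size, as compound 2 carries only a limit: the limit of > 100000 nM in this assay, at which 1 of the 3 values shown sits.

On these data alone, whether an amine or a carboxylic acid at the end of this chain would keep the lower number remains open. So does whether a longer chain ending in acetoxy would lower it further.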